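A few compounds are considered here, and "the series" means these few. Any claim that something is new, unique, unknown or untested is made for them only; others in the source may bear on it.

Working notes on the series. Compound 1 `Cc1cc(C#N)cc(C)c1Oc1nc(NC2CCCN(Cc3ccc(C(N)=O)cc3)C2)nc2ccsc12` and compound 2 `Cc1cc(C#N)cc(C)c1Oc1nc(NC2CCC(NCc3ccc(S(C)(=O)=O)cc3)CC2)nc2ccsc12` share a core and have both been measured in an ADME assay on MT4 cells (Homo sapiens) for cytotoxicity, read by MTT assay, with a stated time of 5 days; on this read-out lower numbers stand for higher toxicity in this test and higher numbers for lower toxicity in this test. In this assay compound 1 gives 19500 nM, and compound 2 gives 75200 nM, the higher of the two numbers, with the gap to compound 1 beyond the scatter. Compound 3 `Cc1cc(C#N)cc(C)c1Oc1nc(NC2CCC(NCc3cccc(C(F)(F)F)c3)CC2)nc2ccsc12` is not yet measured. The change from compound 2 to compound 3 is 3-(trifluoromethyl)phenyl in place of 4-(methylsulfonyl)phenyl on a saturated chain carbon bound to an amine nitrogen. For the measured compounds named here, with only two numbers and no single-point step between measured compounds, a modest drop, toward a lower number than compound 2 and possibly beyond the scatter, is expected: a 1.9-fold lower number from compound 2 to compound 3 (0.27 log units; within the scatter). Compound 3 is therefore estimated at 40000 nM, within 15000 nM to 90000 nM.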

Compound 3, half-maximal cytotoxic concentration: 707 nM
For compound 3 the middle estimate is 57-fold (1.75 log units) above the measured one; measured number below the stated range.
By their numbers in this assay, from the lowest: compound 3; then compound 1; then compound 2.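

In this assay, the group carried on the benzyl amine proves able to move the read-out by a wide margin: 3-(trifluoromethyl)phenyl in place of 4-(methylsulfonyl)phenyl gives a 110-fold lower number from compound 2 to compound 3 (2.03 log units; beyond the scatter). The group that leaves holds 2 hydrogen-bond acceptors and the one that enters holds 0, at 10 heavy atoms each, but no measurement here connects that difference to the step. From the compounds shown here alone, the step changes the substituent and its printed ring number together, so the contribution of each stays open. Going by these compounds, how a carboxylic acid or an unsubstituted phenyl at this place would read in this assay also stays open.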